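A few compounds are considered here, and "the series" means these few. Any claim that something is new, unique, unknown or untested is made for them only; others in the source may bear on it.

Measured so far in a functional assay on A549 cells (Homo sapiens) for antiproliferative activity, read by MTT assay, with a stated time of 72 h; a higher number here means a weaker inhibitor, a lower number a stronger inhibitor:
- compound 1 `O=C1O[C@H]([C@@H](O)Cn2cc(-c3cc(F)cc(F)c3)nn2)C(OCc2ccccc2)=C1OCc1ccccc1`: 41200 nM
- compound 2 `Cc1ccc(-c2cn(C/C=C3\OC(=O)C(OCc4ccccc4)=C3OCc3ccccc3)nn2)cc1`: > 100000 nM
- compound 3 `CCCCCc1ccc(-c2cn(C/C=C3\OC(=O)C(OCc4ccccc4)=C3OCc3ccccc3)nn2)cc1`: > 100000 nM

Among the measured compounds shown here, compound 1 is the only member of the set with a numerical value, and in this assay compound 1 gives 41200 nM. For compound 2 the result is a limit of the assay, > 100000 nM. For compound 3 the result is likewise a limit, > 100000 nM. For the measured compounds named here, the one step between measured neighbours, a step that the two limits leave unreadable from compound 2 to compound 3, cannot be sized, because both ends sit at the limit of > 100000 nM in this assay, at which 2 of the 3 values shown sit.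

Compound 4 `CCCCCCCCCCc1cn(C[C@H](O)[C@H]2OC(=O)C(OCc3ccccc3)=C2OCc2ccccc2)nn1` is not yet measured. It differs from compound 1 by decyl in place of 3,5-difluorophenyl on an aromatic carbon. Going by the values given here, no measured step covers a replacement of this kind: the only recorded step exchanges butyl for hydrogen on a saturated chain carbon and is unreadable. Compound 2 and compound 3 share neither the hydroxyl-bearing linker nor the stereocentres of compound 1 and compound 4, so they do not bear on this step. The expectation for compound 4 therefore rests on compound 1 alone, with a 1.1-fold higher number from compound 1 to compound 4 (0.04 log units; within the scatter) expected to stay within the scatter. Compound 4 is estimated at 45000 nM, between 12000 nM and 150000 nM, with a real chance that only a limit is returned.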

Compound 4, half-maximal inhibitory concentration: 6750 nM
Compound 4: the middle estimate sits 6.7-fold (0.82 log units) above what was measured; measured number below the stated range.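

In this assay, among the compounds shown here, decyl in place of 3,5-difluorophenyl gives a 6.1-fold lower number from compound 1 to compound 4 (0.79 log units; beyond the scatter), the only readable step so far. At this aromatic carbon of the five-membered aromatic ring with 3 nitrogen, an aromatic ring in the substituent is not required for the activity of compound 1, as a chain with no ring gives a lower number on the same core and linker. The data shown give no reason for this step.

This single pair cannot separate the effect of losing the 3,5-difluorophenyl from the effect of the length of the decyl chain, and a shorter chain, a longer chain or a chain ending in an amine at the same carbon would address that. Also open, going by these compounds, is whether the hydroxyl-bearing linker shared by compound 1 and compound 4 matters for this change; the results for compound 2 and compound 3 are both limits of the assay, and the step between them cannot be read.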